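A few compounds are considered here, and "the series" means these few. Any claim that something is new, unique, unknown or untested is made for them only; others in the source may bear on it.

Measured compounds:
compound 1, `CNCc1cc(-c2cccnc2F)n(S(=O)(=O)c2ccsc2)c1`: 98%
compound 2, `CNCc1cn(S(=O)(=O)c2ccc(OC)cn2)c(-c2cccnc2F)c1F`: 95%

Both were tested in a functional assay on the whole organism (strain Jcl:Sprague-Dawley) for inhibition, with Rattus norvegicus as the target, with stated times of 3 min and 3 h, at a dose of 1 mg/kg by the intravenous route; on this read-out higher numbers stand for more inhibition at the one dose given (going by the name of the read-out) and lower numbers for less inhibition. On the numbers shown compound 2, with 95%, has the smaller figure, yet compound 1 at 98% sits within the usual scatter of it, so the two cannot be told apart; both numbers are high at the single dose given.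

Compound 3, `CNCc1cn(S(=O)(=O)c2cnccc2C)c(-c2cccnc2F)c1F`, has not yet been measured in this assay. It differs from compound 2 in one place: 4-methylpyridin-3-yl in place of 5-methoxypyridin-2-yl on a sulfonyl sulfur. For the measured compounds named here, no step between two measured compounds is available to guide a judgement of this change, so the expectation rests only on the high values of compound 1 and compound 2.

For compound 3 the step expected is a number 5 percentage points lower from compound 2 to compound 3 (within the scatter), a modest drop or nothing beyond the scatter. Compound 3 is therefore estimated at 90%, with a range from 70% to 99%.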

Compound 3, a percentage reported as inhibition, in the whole organism at one dose (the size of the read-out at that dose, not a potency): 98%
For compound 3 the middle estimate is 8 percentage points below the measured one; low and high end bracket the measured number.
By their numbers in this assay, from the lowest: compounds 2, 1 and 3 (each within the scatter of the next).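

Placing 4-methylpyridin-3-yl on the sulfonyl sulfur instead of 5-methoxypyridin-2-yl gives the first direct comparison at this position in this assay, and the result is a number 3 percentage points higher from compound 2 to compound 3 (within the scatter). The oxygen of the methoxy group is therefore not needed to keep the number high in this pair, and the position accepts two differently substituted pyridine rings with no difference that can be told from scatter. No measurement is available that would explain this result.

Going by these compounds, it remains open whether a group of another kind on the sulfonyl sulfur, such as an unsubstituted phenyl ring or a pyridine ring carrying a carboxylic acid, would keep the number this high. On these data alone, with values this close together at a single dose, it also remains open whether compound 2 and compound 3 would separate at a lower dose.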